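The compounds below may be only part of what the source reports. "The series", "measured", "known", "first", "only" and "open" are said of these compounds alone.

Measured so far in a functional assay on NCI-H1299 cells (Homo sapiens) for inhibition, read by CCK-8 assay, with a stated time of 72 h, tested at 1 uM; a lower number here means less inhibition of growth, a higher number more inhibition of growth at the concentration tested:
- compound 1 `CN(C)C(=O)c1cc2cnc(Nc3ccc(N)cn3)nc2n1C1CCCC1`: 60.1%
- compound 2 `CN(C)C(=O)c1cc2cnc(Nc3ccc(NC(=O)C4(C(=O)Nc5ccccc5F)CC4)cc3)nc2n1C1CCCC1`: 70.2%
- compound 3 `Nc1ccc(NC(=O)C2(C(=O)Nc3ccc(F)cc3)CC2)cc1F`: 46.2%

Compound 2 stands highest of the three numbers, at 70.2%. Its gaps to both other compounds lie beyond the scatter.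

Compound 4 `CN(C)C(=O)c1cc2cnc(Nc3ccc(NC(=O)C4(C(=O)Nc5ccc(O)cc5)CC4)cc3)nc2n1C1CCCC1`, not yet measured in this assay, carries 4-hydroxyphenyl in place of 2-fluorophenyl on an amide-type nitrogen. Going by the values given here, no two measured compounds differ in one place only, so the series gives no direct reading of this change, and any expectation is a loose one. Compound 4 keeps the core of compound 2, and compound 1, which shares that core without the amide arm, still gives 60.1%. On that basis, a high reading is expected to persist, with little movement from the swap at the far end of the arm. The expected change is a number 5.2 percentage points lower from compound 2 to compound 4 (within the scatter), a small fall not beyond the scatter. For compound 4 the estimated value is 65%, with an expected range of 50% to 80%.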

Compound 4, percent growth inhibition at one concentration: 87.4%
Compound 4: the middle estimate sits 22.4 percentage points below what was measured, and the stated range ends below it.
By their numbers in this assay, from the lowest: compound 3; then compound 1; then compound 2; then compound 4.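

In this assay, going by these compounds alone, 4-hydroxyphenyl in place of 2-fluorophenyl on an amide-type nitrogen gives a number 17.2 percentage points higher from compound 2 to compound 4 (beyond the scatter), the only one-place comparison so far. The group on this nitrogen therefore matters to growth inhibition at the concentration tested, even with the shared core and the rest of the arm held constant. No measurement shown explains the rise.

This step changes the ring substituent and its printed ring position together, so it cannot show which of the two matters. 2-Hydroxyphenyl, 4-methoxyphenyl and 4-aminophenyl on the same nitrogen of compound 2 would help separate those two changes and test whether the hydroxyl can be replaced.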